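The source may hold more compounds than are shown below. What is called first, only, known or untested is meant among the compounds shown, and "the series" means these compounds.

Of the compounds shown here, three that share one core have been tested in a functional assay on MKN-45 cells (Homo sapiens) for cytotoxicity, read by MTT assay, with a stated time of 72 h; on this read-out lower numbers stand for stronger inhibition and higher numbers for weaker inhibition. Compound 1 `CN(C)CCn1cnnc1-c1cc(Oc2ccc(NC(=O)N/N=C/c3cccc(O)c3)cc2F)ccn1` gives 1370 nM. Compound 2 `CN(C)CCn1cnnc1-c1cc(Oc2ccc(NC(=O)N/N=C/c3cccc(Cl)c3Cl)cc2F)ccn1` gives 51 nM. Compound 3 `COc1ccc(/C=N/NC(=O)Nc2ccc(Oc3ccnc(-c4nncn4CCN(C)C)c3)c(F)c2)cc1O` gives 2510 nM, the highest of the three numbers; the step of a 1.8-fold higher number from compound 1 to compound 3 (0.26 log units; within the scatter) is within the scatter, while the step of a 49-fold higher number from compound 2 to compound 3 (1.69 log units; beyond the scatter) is a large one. The next compound, compound 4 `CN(C)CCn1cnnc1-c1cc(Oc2ccc(NC(=O)N/N=C/c3ccc(Cl)cc3Cl)cc2F)ccn1`, differs from compound 3 at a single place: 2,4-dichlorophenyl in place of 3-hydroxy-4-methoxyphenyl on a carbon with a double bond to nitrogen. Among the compounds with values here, two measured steps bear on this change. The step of a 27-fold lower number from compound 1 to compound 2 (1.43 log units; beyond the scatter) and the step of a 49-fold higher number from compound 2 to compound 3 (1.69 log units; beyond the scatter) both show the dichlorophenyl compound at the markedly lower number. Within the data shown here, compound 4 carries a 2,4-dichlorophenyl rather than the 2,3-dichlorophenyl of compound 2, and no measured step compares these two groups with each other. A large fall is therefore expected for compound 4, a 31-fold lower number from compound 3 to compound 4 (1.50 log units; beyond the scatter), landing close to compound 2. Compound 4 is estimated at 80 nM, within a range from 30 nM to 250 nM.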

Compound 4, half-maximal inhibitory concentration: 750 nM
Compound 4: middle estimate off by 9.4-fold (0.97 log units), on the low side; the measured number lies above the stated range.
By their numbers in this assay, from the lowest: compound 2; then compounds 4, 1 and 3 (each within the scatter of the next, the first and the last beyond it).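

Changing only where the two chlorines sit, 2,4-dichlorophenyl in place of 2,3-dichlorophenyl, gives a large step (a 15-fold higher number from compound 2 to compound 4 (1.17 log units; beyond the scatter)), so on this core the placing of the chlorines counts, not merely their presence. The low number of compound 2 is therefore not shared by every dichlorophenyl: in place of 3-hydroxy-4-methoxyphenyl, 2,4-dichlorophenyl brings only a modest step (a 3.3-fold lower number from compound 3 to compound 4 (0.52 log units; beyond the scatter)), and in place of 3-hydroxyphenyl it leaves no clear difference (a 1.8-fold lower number from compound 1 to compound 4 (0.26 log units; within the scatter)). No measurement at hand explains why the two chlorine patterns differ.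

The compounds shown leave open whether the low number of compound 2 needs chlorine at all, or whether a 2,3-difluorophenyl or 2,3-dimethylphenyl group would match it. They also cannot tell whether a single chlorine, as in 3-chlorophenyl or 2-chlorophenyl, would be enough.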